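The source may report more compounds than this note shows. Statements on the series, on what has been measured and on what is new or still open speak of the compounds shown alone.

The measured compounds, each in an ADME assay on Vero cells (Chlorocebus sabaeus) for cytotoxicity, with a stated time of 4 days; on this read-out higher numbers stand for weaker inhibition and lower numbers for stronger inhibition:

Compound 1, `Cc1ccccc1OCc1cn(-c2ccc(S(=O)(=O)N3CCc4ccccc4C3)cc2)nn1`: in this assay compound 1 gives > 50 ug/mL, which is a limit of the assay and not a number.
Compound 2, `COc1cc2c(cc1OC)CN(S(=O)(=O)c1ccc(-n3cc(COc4ccc(C=O)cc4)nn3)cc1)CC2`: in this assay compound 2 gives > 50 ug/mL, again a limit of the assay.
Compound 3, `O=S(=O)(c1ccc(-n2cc(COc3ccccc3)nn2)cc1)N1CCc2ccccc2C1`: in this assay compound 3 gives > 50 ug/mL, also a limit of the assay.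

Compound 2 therefore stands at the limit, and so does every other measured compound, as shown by the limit of > 50 ug/mL in this assay, at which 3 of the 3 values shown sit. Going by the values given here, the only step between two measured compounds that differ in one place, a step that the two limits leave unreadable from compound 1 to compound 3, cannot be sized because the limit of > 50 ug/mL in this assay, at which 3 of the 3 values shown sit, holds both of its ends.

The unmeasured compound 4, `COc1cc2c(cc1OC)CN(S(=O)(=O)c1ccc(-n3cc(COc4ccc(C)cc4)nn3)cc1)CC2`, differs from compound 2 by methyl in place of formyl on an aromatic carbon. Among the compounds with values here, no measured step bears on this change in a readable way, so there is no basis for expecting any movement beyond the scatter. Compound 4 is expected to give 80 ug/mL, within 50 ug/mL to 200 ug/mL. The expected step is a step that the limit leaves unreadable from compound 2 to compound 4, which is estimated as none beyond the scatter, most likely reported again as a limit.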

Compound 4, half-maximal inhibitory concentration: > 50 ug/mL
Compound 4: a limit, no number; the forecaster's own chance of this, stated with the estimate: 90%; the middle value does not contradict the limit.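

Compound 2 and compound 4 both stand at a limit of the assay, not at a number, so no step between them can be read, because the result is again: the limit of > 50 ug/mL in this assay, at which 4 of the 4 values shown sit.

The compounds shown leave open whether swapping formyl for methyl changes anything in this assay, and at what concentration any of the four compounds would inhibit the cells.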